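The compounds below may be only part of what the source reports. "The series", "measured", "known", "first", "only" and "open" are said of these compounds alone.

Two compounds share one core and differ only in the group on the outer phenyl ring. Compound 1 `FC(F)(F)c1cccc(-c2nc3cnc(Nc4ccccn4)cc3[nH]2)c1` carries a trifluoromethyl group there, and compound 2 `FC(F)(F)Oc1ccc(-c2nc3cnc(Nc4ccccn4)cc3[nH]2)cc1` carries a trifluoromethoxy group. In a physicochemical assay for solubility, using the shake flask method, measured as kinetic solubility, with a stated time of 20 h, at pH 2 (a lower number here means a less soluble compound, a higher number a more soluble compound), compound 1 gives 21000 nM, and in this assay compound 2 gives 26000 nM. These two numbers lie within the usual scatter of each other, so neither compound can be called more or less soluble than the other; compound 1 stands beside compound 2 in the same range.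

Compound 3 `COc1cccc(Nc2cc3[nH]c(-c4cccc(C(F)(F)F)c4)nc3cn2)n1` is not yet measured. It differs from compound 1 in one place: methoxy in place of hydrogen on an aromatic carbon. Among the measured compounds shown here, no pair of measured compounds shows this same change, so its effect cannot be read from the data. The expectation for compound 3 therefore rests on the starting point of compound 1 at 21000 nM and on the fact that the change adds no ring and no charge. The expected step from compound 1 to compound 3 is a 1.4-fold lower number from compound 1 to compound 3 (0.15 log units; within the scatter), a small move downward that may stay within the scatter. For compound 3 the estimated solubility in this assay is 15000 nM, with a range from 5000 nM to 40000 nM.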

Compound 3, solubility: 85000 nM
Beside the measured number, compound 3's estimate is 5.7-fold (0.75 log units) below it, and the stated range ends below it.
By their numbers in this assay, from the lowest: compounds 1 and 2 (each within the scatter of the next); then compound 3.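

In this assay, replacing pyridin-2-yl with 6-methoxypyridin-2-yl gives a 4.0-fold higher number from compound 1 to compound 3 (0.61 log units; beyond the scatter). This change sits on an aromatic carbon next to the ring nitrogen, and the step lies beyond the scatter. Compound 1 and compound 2 differ only in the group on the outer phenyl ring and lie within the scatter of each other, so they gave no view of what a change on the pyridin-2-yl group does. Nothing measured here accounts for the rise, and this single pair of compounds cannot establish a general pattern.

From the compounds shown here alone, it remains open whether the rise is specific to methoxy or would also appear with another group at the same place, such as an amine, a fluorine atom or a longer chain like ethoxy. Going by these compounds, it is also open whether the same methoxy change would produce a step of similar size on compound 2, which carries trifluoromethoxy on the outer phenyl ring in place of the trifluoromethyl group of compound 1.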